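Series notes: aryl ether variations at the pyridine

A few compounds are considered here, and "the series" means these few. Any claim that something is new, unique, unknown or untested is made for them only; others in the source may bear on it.

Three compounds are in hand. In an assay on membranes from brain for displacement of a labelled ligand from Neuronal acetylcholine receptor; alpha4/beta2 (Rattus norvegicus) (on this read-out lower numbers stand for stronger inhibition and higher numbers for weaker inhibition), compound 1 `CN1CCC[C@H]1COc1cccnc1[N+](=O)[O-]` gives 9000 nM, compound 2 `CN1CCC[C@H]1COc1cnccc1Br` gives 28 nM, and compound 3 `CCCCc1cncc(OC[C@@H]2CCCN2C)c1` gives 0.16 nM. Compound 3 thus carries the lowest number of the three; its gap to compound 2 and its wider gap to compound 1 both lie beyond the scatter, so on these data it is the strongest binder of the set. Compound 4 `CN1CCC[C@H]1COc1cncc(N)c1` is not yet measured and differs from compound 3 as amino in place of butyl on an aromatic carbon. Among the compounds with values here, no measured pair isolates this change, so the expected step from compound 3 to compound 4, estimated as a 19-fold higher number from compound 3 to compound 4 (1.27 log units; beyond the scatter), is an increase in the number beyond the scatter. For compound 4 the estimate in this assay is 3 nM, expected between 0.3 nM and 30 nM.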

Compound 4, inhibition constant: 0.63 nM
Compound 4: the middle estimate sits 4.8-fold (0.68 log units) above what was measured, within the range that was stated.
By their numbers in this assay, from the lowest: compound 3; then compound 4; then compound 2; then compound 1.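

The position two atoms from the ring nitrogen accepts a very different group at only a modest cost in this assay (a 3.9-fold higher number from compound 3 to compound 4 (0.60 log units; beyond the scatter)). The butyl chain is thus not required for a low number here: compound 4 still gives 0.63 nM in this series. Nothing on hand explains the step.

On these data alone, it remains open whether an ethyl chain, a dimethylamino group or a carboxylic acid at this position would keep the number as low. The two compounds also cannot separate loss of butyl from gain of amino.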